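The source may report more compounds than this note shows. Statements on the series, on what has been measured and on what is new or still open speak of the compounds shown alone.

Working notes on the series, read in a functional assay (trachea) with Cavia porcellus as the target; a higher number here means a weaker inhibitor, a lower number a stronger inhibitor. Compound 1 (`Cn1nc(-c2cccnc2)c2ccccc2c1=O`) gives 11500 nM, compound 2 (`CC(=O)Cn1nc(-c2cccnc2)c2ccccc2c1=O`) gives 40700 nM, and compound 3 (`CC(=O)OCCn1nc(-c2cccnc2)c2ccccc2c1=O`) gives 9770 nM. Compound 3 stands at the low end of these numbers, a place it shares with compound 1, as the data show a 1.2-fold lower number from compound 1 to compound 3 (0.07 log units; within the scatter). Compound 2 stands apart from that pair, with a 3.5-fold higher number from compound 1 to compound 2 (0.55 log units; beyond the scatter) and a 4.2-fold lower number from compound 2 to compound 3 (0.62 log units; beyond the scatter).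

The next compound is compound 4 (`O=C(c1cccs1)n1nc(-c2cccnc2)c2ccccc2c1=O`), which has (thiophen-2-yl)carbonyl in place of 2-acetoxyethyl on an aromatic nitrogen. Among the measured compounds shown here, all three measured steps change only a saturated chain on that nitrogen, and none of the measured compounds has a carbonyl bound directly to it or a five-membered aromatic ring. These steps therefore bear on the change only indirectly, by showing how far the numbers have moved at this place. The largest of them stays modest, so the expected step in this assay is small, with a slight lean towards a higher number and no clear move beyond the scatter. The expected change is a 1.4-fold higher number from compound 3 to compound 4 (0.16 log units; within the scatter). For compound 4 the estimate is 14000 nM, with an expected range of 4500 nM to 45000 nM.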

Compound 4, half-maximal inhibitory concentration: 12300 nM
The estimate for compound 4 lay 1.1-fold (0.06 log units) above the measured number; measured number inside the range.
By their numbers in this assay, from the lowest: compounds 3, 1 and 4 (each within the scatter of the next); then compound 2.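

In this assay the aromatic nitrogen carries a (thiophen-2-yl)carbonyl group, with its carbonyl bound directly to that nitrogen and its five-membered aromatic ring, and the reading stays within the scatter of the chain compounds: there is a 1.3-fold higher number from compound 3 to compound 4 (0.10 log units; within the scatter) and a 1.1-fold higher number from compound 1 to compound 4 (0.03 log units; within the scatter) on the same nitrogen. Among the compounds shown here, the methyl, 2-acetoxyethyl and (thiophen-2-yl)carbonyl groups thus read alike here, even though the last is the first group to bring a ring to this place. Compound 2, with its 2-oxopropyl group, remains the only one apart, now also against the new group with a 3.3-fold lower number from compound 2 to compound 4 (0.52 log units; beyond the scatter) in the same assay. Nothing at hand gives a reason for this pattern or for the separate position of the 2-oxopropyl group.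

From the compounds shown here alone, whether the reading of compound 4 depends on the carbonyl bound to the nitrogen or on the thiophene ring stays open, and a plain acetyl or a benzoyl group on the same nitrogen would separate the two. Also open, going by these compounds, is how a chain ending in an amine or a carboxylic acid would read at this place in this assay on the shared core.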